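The source may hold more compounds than are shown below. What is called first, only, known or untested is meant among the compounds shown, and "the series" means these compounds.

Measured in a physicochemical assay for lipophilicity, measured as octanol-water partition; on this read-out lower numbers stand for lower lipophilicity and higher numbers for higher lipophilicity:
- compound 1 `O=C(COc1cccc2ccccc12)N/N=C/c1cccc(O)c1`: 3.73
- compound 2 `O=C(COc1cccc2ccccc12)N/N=C/c1ccccc1Br`: 4.81
- compound 3 `O=C(COc1cccc2ccccc12)N/N=C/c1ccc([N+](=O)[O-])cc1`: 3.97

On these numbers, compound 1 and compound 3 cannot be told apart, while compound 2 stands clearly higher than both. Compound 4 `CSc1ccc(/C=N/NC(=O)COc2cccc3ccccc23)cc1` shares the core of compound 3 and changes one group: methylsulfanyl in place of nitro on an aromatic carbon. In words, this is methylsulfanyl in place of nitro on an aromatic carbon.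

Among the measured compounds shown here, only one measured step bears on this, and only loosely: a number 1.08 log units higher from compound 1 to compound 2 (beyond the scatter). It too swaps a group on an aromatic ring, and the group that enters in compound 2 also holds neither oxygen nor nitrogen. As the two swaps are not the same, a rise smaller than that large step is expected in this assay. The expected change is a number 0.63 log units higher from compound 3 to compound 4 (beyond the scatter). For compound 4 the estimated value is 4.6, with an expected range from 4.2 to 5.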

Compound 4, partition coefficient: 4.11
Compound 4: middle estimate off by 0.49 log units, on the high side, and the stated range ends above it.
By their numbers in this assay, from the lowest: compounds 1, 3 and 4 (each within the scatter of the next, the first and the last beyond it); then compound 2.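

In this assay methylsulfanyl in place of nitro gives a number 0.14 log units higher from compound 3 to compound 4 (within the scatter) and so leaves these two groups indistinguishable at this position. The wider swaps on the same core still register, with a number 0.70 log units lower from compound 2 to compound 4 (beyond the scatter) and a number 0.38 log units higher from compound 1 to compound 4 (beyond the scatter) as modest steps. No measured evidence here explains why nitro and methylsulfanyl land so close together.

Going by these compounds, whether an amine or a carboxylic acid at this position would shift the number further remains open. So does whether the near-match between methylsulfanyl and nitro holds on other aromatic carbons of this ring.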